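Sulfonamide series on PC-3 cells: swapping the sulfonyl aryl

The compounds below may be only part of what the source reports. "The series", "measured", "known", "first", "only" and "open" are said of these compounds alone.

Measured compounds:
Compound 1 `COc1ccc(CN(c2cc(OC)c(OC)c(OC)c2)S(=O)(=O)c2ccc(OC)c(OC)c2)cc1` – 20100 nM
Compound 2 `COc1cc(N(Cc2nc3ccccc3[nH]2)S(=O)(=O)c2ccc(Br)cc2)cc(OC)c1OC` – 6890 nM

In a functional assay on PC-3 cells (Homo sapiens) for inhibition, read by MTT assay, with a stated time of 48 h (on this read-out higher numbers stand for weaker inhibition and lower numbers for stronger inhibition), compound 2 gives 6890 nM, the lower of the two numbers recorded so far. In this assay compound 1 gives 20100 nM, a step beyond the usual scatter, so compound 2 stands as the stronger inhibitor of the pair. The two compounds differ at more than one place, so no single change can be read out of that gap.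

Compound 3 `COc1ccc(S(=O)(=O)N(Cc2nc3ccccc3[nH]2)c2cc(OC)c(OC)c(OC)c2)cc1OC` is the next compound to be measured. Relative to compound 2 the change is 3,4-dimethoxyphenyl in place of 4-bromophenyl on a sulfonyl sulfur. Compound 1 also carries the 3,4-dimethoxyphenyl on its sulfonyl sulfur, yet it differs from compound 3 elsewhere as well, so its value is only a loose pointer. Among the compounds with values here, with no single-change step in hand, the expectation is for at most a modest movement, most likely towards a slightly higher number. The estimate for compound 3 in this assay is 9000 nM, within 3000 nM to 30000 nM, which would mean a step of a 1.3-fold higher number from compound 2 to compound 3 (0.12 log units; within the scatter).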

Compound 3, half-maximal inhibitory concentration: 30400 nM
Compound 3: the middle estimate sits 3.4-fold (0.53 log units) below what was measured; measured number above the stated range.
By their numbers in this assay, from the lowest: compound 2; then compounds 1 and 3 (each within the scatter of the next).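

In this assay, within the data shown here, 3,4-dimethoxyphenyl in place of 4-bromophenyl on a sulfonyl sulfur gives a 4.4-fold higher number from compound 2 to compound 3 (0.64 log units; beyond the scatter), the first single-place reading and one beyond the scatter, so the group on the sulfonyl sulfur does shift the number, and compound 2 is the stronger inhibitor of this pair. With 3,4-dimethoxyphenyl held on the sulfonyl sulfur, 1H-benzimidazol-2-yl in place of 4-methoxyphenyl on a saturated chain carbon bound to a sulfonamide nitrogen gives a 1.5-fold higher number from compound 1 to compound 3 (0.18 log units; within the scatter), which lies within the scatter, so this second change has no effect that can be told apart in this sulfonyl setting. No supporting data bear on why the 4-bromophenyl compound gives the lower number.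

The compounds shown leave open whether the gain follows the bromine itself or the absence of the two methoxy groups, which a plain phenyl, a 4-chlorophenyl or a 4-methoxyphenyl on the sulfonyl sulfur would begin to separate. Also open, on these data alone, is how far this place tolerates an amine or a carboxylic acid on that aryl ring, and whether the 4-bromophenyl result carries over to the 4-methoxyphenyl chain of compound 1.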